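Thioether chain length on the shared core

The source may hold more compounds than are shown below. What is called first, only, known or untested is meant among the compounds shown, and "the series" means these compounds.

Measured so far:
Compound 1, `Cc1ccc(CSc2n[nH]c(-n3[se]c4ccccc4c3=O)n2)cc1`, gives in an ADME assay on L929 cells (Mus musculus) for antiproliferative activity, read by CCK-8 assay, with a stated time of 48 h (on this read-out higher numbers stand for weaker inhibition and lower numbers for stronger inhibition), a limit of the assay, > 50000 nM.
Compound 2, `CCCCSc1n[nH]c(-n2[se]c3ccccc3c2=O)n1`, gives in this assay 30400 nM.

Compound 2 holds the only number shown; the other value is a limit, (the limit of > 50000 nM in this assay, at which 1 of the 2 values shown sits). For the measured compounds named here, the one measured step, an at least 1.6-fold lower number from compound 1 to compound 2 (0.21 log units; that floor lies within the scatter), runs from that limit to the number of compound 2.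

Compound 3, `CCCCCSc1n[nH]c(-n2[se]c3ccccc3c2=O)n1`, differs from compound 2 as methyl in place of hydrogen on a saturated chain carbon, four bonds along the chain from a sulfur. Going by the values given here, no measured step adds a methyl on the chain, so the butyl-to-phenyl step gives no direct guide. For compound 3 the expected step in this assay is a 1.2-fold lower number from compound 2 to compound 3 (0.08 log units; within the scatter), none beyond the scatter. Compound 3 is therefore estimated at 25000 nM, between 10000 nM and 60000 nM.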

Compound 3, half-maximal inhibitory concentration: 33500 nM
Compound 3: middle estimate off by 1.3-fold (0.13 log units), on the low side; low and high end bracket the measured number.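

Methyl in place of hydrogen on a saturated chain carbon, four bonds along the chain from a sulfur, lengthens the chain itself, and in this assay it gives a 1.1-fold higher number from compound 2 to compound 3 (0.04 log units; within the scatter). Exchanging the 4-methylphenyl group for a butyl chain gives an at least 1.4-fold lower number from compound 1 to compound 3 (0.17 log units; that floor lies within the scatter). The value of compound 1 is a limit, not a number: the limit of > 50000 nM in this assay, at which 1 of the 3 values shown sits.

Still open, on these data alone, is whether a longer chain, or an amine or a carboxylic acid at the end of the chain, would shift the number beyond the scatter.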